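Swapping isopropyl for iodo on a weaker anilide

The source may hold more compounds than are shown below. What is called first, only, known or untested is meant among the compounds shown, and "the series" means these compounds.

Measured so far:
Compound 1, `CCCC(=O)Nc1ccc(S(=O)(=O)Oc2ccccc2C(C)C)cc1`: 4900 nM
Compound 2, `CCCC(=O)Nc1ccc(S(=O)(=O)Oc2ccccc2I)cc1`: 11000 nM
Compound 3, `CC(C)C(=O)Nc1ccc(S(=O)(=O)Oc2ccccc2C(C)C)cc1`: 14000 nM

Of the compounds shown here, three have been tested in a functional assay on HT-29 cells (Homo sapiens) for antiproliferative activity, read by sulforhodamine B assay, with a stated time of 48 h; on this read-out higher numbers stand for weaker inhibition and lower numbers for stronger inhibition. Compound 1 gives 4900 nM. Replacing one group on compound 1, (iodo in place of isopropyl on an aromatic carbon), yields compound 2, and this change made a 2.2-fold higher number from compound 1 to compound 2 (0.35 log units; beyond the scatter). Compound 3 differs from compound 1 in the amide part, (isopropyl in place of propyl on a carbonyl carbon), and that change made a 2.9-fold higher number from compound 1 to compound 3 (0.46 log units; beyond the scatter). Compound 3 and compound 2 lie within the scatter of each other, so neither can be ranked above the other.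

Compound 4, `CC(C)C(=O)Nc1ccc(S(=O)(=O)Oc2ccccc2I)cc1`, has not yet been measured. It carries the same change relative to compound 3 that compound 2 carries relative to compound 1: iodo in place of isopropyl on an aromatic carbon. Both places read the same, so this is the same change applied to a different core. Since that change made a 2.2-fold higher number from compound 1 to compound 2 (0.35 log units; beyond the scatter), a step of similar size is expected here, and compound 4 is estimated to show a 2.0-fold higher number from compound 3 to compound 4 (0.30 log units; within the scatter) in this assay, though the weaker starting point of compound 3 adds uncertainty. The expected value for compound 4 is therefore 28000 nM, in a range from 11000 nM to 65000 nM.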

Compound 4, half-maximal inhibitory concentration: 13000 nM
Compound 4: the middle estimate sits 2.2-fold (0.33 log units) above what was measured; low and high end bracket the measured number.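

In this assay, putting iodo in place of isopropyl on the aromatic carbon gave a 1.1-fold lower number from compound 3 to compound 4 (0.03 log units; within the scatter), and putting isopropyl in place of propyl on the carbonyl carbon gave a 1.2-fold higher number from compound 2 to compound 4 (0.07 log units; within the scatter). Each new step lies within the scatter while its earlier counterpart lay beyond it, but this contrast is not firm, as the gap between the two iodo steps is itself within the scatter expected for a pair of steps: the same change on two cores in this assay, a 2.2-fold higher number (0.35 log units; beyond the scatter) from compound 1 to compound 2 and a 1.1-fold lower number (0.03 log units; within the scatter) from compound 3 to compound 4, 2.4-fold (0.38 log units) apart, within the scatter of two such steps The same holds for the change on the carbonyl carbon, so the data show neither that a change carries over at full size nor that its effect depends on the core: the same change on two cores in this assay, a 2.9-fold higher number (0.46 log units; beyond the scatter) from compound 1 to compound 3 and a 1.2-fold higher number (0.07 log units; within the scatter) from compound 2 to compound 4, 2.4-fold (0.38 log units) apart, within the scatter of two such steps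

From the compounds shown here alone, these compounds form a single small square, so it remains open whether the same picture would hold for other groups on the aromatic carbon, such as chloro or methoxy. Going by these compounds, it also remains open how a longer chain or a cyclopropyl group on the carbonyl carbon would behave on either core.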